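The source may hold more compounds than are shown below. What is called first, only, known or untested is meant among the compounds shown, and "the series" means these compounds.

Measured compounds, with their values in an assay on isolated protein for inhibition of long-chain fatty acid transport protein 1 (Homo sapiens); a lower number here means a stronger inhibitor, a higher number a weaker inhibitor:
compound 1 `CCc1ccc2oc(CSc3nnc(CNc4ccccc4)n3CC)nc2c1` gives > 1000 nM, which is a limit of the measurement and not a number.
compound 2 `CCOC(=O)c1ccc(NC(=O)CSc2nnc(CSCc3ccccc3)n2CC)cc1` gives 7600 nM.
compound 3 `CCn1nnc(-c2ccc(NC(=O)CSc3nnc(CNc4ccccc4)n3CC)cc2)n1` gives > 1000 nM, again a limit and not a number.

Compound 1 therefore has no fixed place among the numbers shown; what is known of it is only (the limit of > 1000 nM in this assay, at which 2 of the 3 values shown sit). For the measured compounds named here, compound 2 supplies the only numerical value in the set. Going by the values given here, no two measured compounds differ in a single place, so no measured step is available for this assay.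

Compound 4 `CCn1c(CNc2ccccc2)nnc1SCc1nc2cc(Cl)ccc2o1` is the unmeasured partner of compound 1. It differs by chloro in place of ethyl on an aromatic carbon of the fused ring system; everything else in the shared core of compound 1 is kept.

Expected size of step in this assay: nothing beyond the scatter, with no direction assigned, since compound 1 offers only a limit as a starting point; the step that the limit leaves unreadable from compound 1 to compound 4 is the estimate. Compound 4 is expected at 5000 nM, within 1000 nM to 30000 nM.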

Compound 4, half-maximal inhibitory concentration: > 1000 nM
Compound 4: only a limit was reported; the forecaster's own chance of this, stated with the estimate: 60%; the middle value does not contradict the limit.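

No step can be read between compound 1 and compound 4: both are reported only as limits in this assay. Whether chloro in place of ethyl on an aromatic carbon changes inhibition at all stays open, since most of the series rests on one limit: the limit of > 1000 nM in this assay, at which 3 of the 4 values shown sit.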